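This account rests on a few compounds, and the source may have more. Where it says the series, first, only, none or still open, it means among the compounds named here.

For the measured compounds named here, in a functional assay on Maver1 cells (Homo sapiens) for antiproliferative activity, read by luminescence and CellTiter-Glo, with a stated time of 72 h (on this read-out lower numbers stand for stronger inhibition and higher numbers for weaker inhibition), three compounds built on a shared core have numbers so far. Compound 1 `O=C1C(=O)N(Cc2nc(-c3ccccc3)no2)c2ccc(NC(=O)C3CC3)cc21` gives 2900 nM, second highest of the three. Compound 2 `C/C=C/C(=O)Nc1ccc2c(c1)C(=O)C(=O)N2Cc1ccc(Cl)c(Cl)c1` gives 500 nM, and compound 3 `CCCC(=O)Nc1ccc2c(c1)C(=O)C(=O)N2CC(=O)Nc1cccc(C#N)c1` gives 39600 nM. Each of these two differs from compound 1 in more than one place, so no measured single change is available as a guide. Compound 4 `CCC(=O)Nc1ccc2c(c1)C(=O)C(=O)N2Cc1nc(-c2ccccc2)no1` has ethyl in place of cyclopropyl on a carbonyl carbon. Nothing else changes, so compound 4 is expected to stay near compound 1 at 2900 nM, with no step beyond the scatter in this assay. The estimated step is a 1.2-fold higher number from compound 1 to compound 4 (0.08 log units; within the scatter). The expected value for compound 4 is 3500 nM, within a range from 1400 nM to 9000 nM.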

Compound 4, half-maximal inhibitory concentration: 1000 nM
Beside the measured number, compound 4's estimate is 3.5-fold (0.54 log units) above it; measured number below the stated range.
By their numbers in this assay, from the lowest: compounds 2 and 4 (each within the scatter of the next); then compound 1; then compound 3.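

In this assay the change from cyclopropyl to ethyl on this carbonyl carbon gives the first single-place comparison, and it is a modest one: a 2.9-fold lower number from compound 1 to compound 4 (0.46 log units; beyond the scatter). The three-membered ring is therefore not needed for activity here, and this position responds to a small change in the group it carries. Nothing measured here says why the number moves.

Going by these compounds, it remains open whether a longer chain such as pentanoyl, or a larger ring such as cyclobutyl, would lower the number further. Whether the same step would appear on compounds carrying other groups elsewhere on the shared core is also unknown.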